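Fluoro for Chloro on the Triazole Aryl Ring

The source may report more compounds than this note shows. Statements on the series, on what has been measured and on what is new or still open speak of the compounds shown alone.

Measured compounds:
Compound 1 `COc1cc2c(Oc3ccc(NC(=O)c4cn(-c5ccccc5F)nn4)cc3F)ccnc2cc1OCCCN1CCCCC1`: in a functional assay on MKN-45 cells (Homo sapiens) for cytotoxicity, read by MTT assay, with a stated time of 72 h (on this read-out higher numbers stand for weaker inhibition and lower numbers for stronger inhibition), compound 1 gives 1290 nM.
Compound 2 `COc1cc2c(Oc3ccc(NC(=O)c4cn(-c5ccccc5)nn4)cc3F)ccnc2cc1OCCCN1CCC(C)CC1`: compound 2 gives 90 nM.
Compound 3 `COc1cc2c(Oc3ccc(NC(=O)c4cn(-c5ccccc5Cl)nn4)cc3F)ccnc2cc1OCCCN1CCC(C)CC1`: compound 3 gives 240 nM.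
Compound 4 `COc1cc2c(Oc3ccc(NC(=O)c4cn(-c5ccccc5F)nn4)cc3F)ccnc2cc1OCCCN1CCC(C)CC1`: not yet measured.

Among the three measured numbers, compound 3 stands second highest. Its nearest neighbour is compound 2, which lies lower, and its furthest is compound 1, which lies higher; both gaps are beyond the scatter. Going by the values given here, only one single-point step is known in this assay, namely a 2.7-fold higher number from compound 2 to compound 3 (0.43 log units; beyond the scatter), which shows that placing chloro on this aromatic carbon raised the number modestly.

Compound 4 differs from compound 3 by fluoro in place of chloro on an aromatic carbon, on an aromatic carbon of a six-membered aromatic ring of carbon only, ortho to a large group. Among the compounds with values here, no measured pair shows fluoro in place of chloro directly. Compound 1 carries the same fluoro but a different amine, so its value cannot be read as a step. The chloro step from compound 2 to compound 3 bears on it only by indicating that a halogen at this carbon did not lower the number.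

The step from compound 3 to compound 4 is therefore expected to be small, a 1.0-fold higher number from compound 3 to compound 4 (0.02 log units; within the scatter), with no clear direction beyond the scatter. Compound 4 is estimated at 250 nM, within a range from 90 nM to 800 nM.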

Compound 4, half-maximal inhibitory concentration: 130 nM
Compound 4: middle estimate off by 1.9-fold (0.28 log units), on the high side, within the range that was stated.
By their numbers in this assay, from the lowest: compounds 2, 4 and 3 (each within the scatter of the next, the first and the last beyond it); then compound 1.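

In this assay, fluoro in place of chloro gives a 1.8-fold lower number from compound 3 to compound 4 (0.27 log units; within the scatter), and fluoro in place of hydrogen gives a 1.4-fold higher number from compound 2 to compound 4 (0.16 log units; within the scatter), so on this aromatic carbon fluoro cannot be told apart from either chloro or hydrogen, even though the chloro step itself, a 2.7-fold higher number from compound 2 to compound 3 (0.43 log units; beyond the scatter), lies beyond the scatter. The new compound also gives the first single-place comparison away from this ring: methyl in place of hydrogen on a saturated ring carbon gives a 9.9-fold lower number from compound 1 to compound 4 (1.00 log units; beyond the scatter), a larger step than any seen on the aromatic carbon. No measured evidence is available to account for any of these steps.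

The compounds shown leave open how a bromo, methoxy or trifluoromethyl group on this aromatic carbon would compare with fluoro and chloro, and whether fluoro would behave the same way on other carbons of this ring. As far as these compounds go, it also remains open whether the methyl step carries over to the phenyl and 2-chlorophenyl compounds, and how an ethyl or hydroxyl group on the same saturated ring carbon would compare with methyl.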